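Sulfonyl aryl swap: 3-nitrophenyl replaces 2,4-dimethoxyphenyl

The source may hold more compounds than are shown below. What is called first, only, known or untested is meant among the compounds shown, and "the series" means these compounds.

Compound 2 `COc1ccc(S(=O)(=O)N(C)c2ccc3[nH]c(-c4n[nH]c5ccccc45)cc3n2)c(OC)c1` gives 10800 nM in a functional assay on SMMC-7721 cells (Homo sapiens) for antiproliferative activity, read by MTT assay, with a stated time of 72 h (a lower number here means a stronger inhibitor, a higher number a weaker inhibitor), the highest of the two numbers measured; compound 1 `COc1ccc(OC)c(S(=O)(=O)N(C)c2ccc3[nH]c(-c4n[nH]c5ccccc45)cc3n2)c1` gives 4280 nM. Compound 3 `CN(c1ccc2[nH]c(-c3n[nH]c4ccccc34)cc2n1)S(=O)(=O)c1cccc([N+](=O)[O-])c1` carries the change (3-nitrophenyl in place of 2,4-dimethoxyphenyl on a sulfonyl sulfur). For the measured compounds named here, the only measured step, a 2.5-fold higher number from compound 1 to compound 2 (0.40 log units; beyond the scatter), bears on it loosely: it shows that altering the aryl group on the sulfonyl sulfur shifts the number beyond the scatter, but no step to a nitro-bearing aryl exists. Compound 3 is therefore expected near compound 2, with a wide range, as a 1.8-fold lower number from compound 2 to compound 3 (0.26 log units; within the scatter). The estimate for compound 3 is 6000 nM, between 1500 nM and 25000 nM.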

Compound 3, half-maximal inhibitory concentration: 5070 nM
Compound 3: middle estimate off by 1.2-fold (0.07 log units), on the high side; low and high end bracket the measured number.
By their numbers in this assay, from the lowest: compounds 1 and 3 (each within the scatter of the next); then compound 2.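

On the sulfonyl sulfur in this assay, the aryl group need not carry methoxy groups: 3-nitrophenyl gives a 2.1-fold lower number from compound 2 to compound 3 (0.33 log units; beyond the scatter), while against 2,5-dimethoxyphenyl it gives a 1.2-fold higher number from compound 1 to compound 3 (0.07 log units; within the scatter). Of the three aryl groups, only 2,4-dimethoxyphenyl stands apart from the others, with compound 1 and compound 3 indistinguishable. No measurement shown accounts for these differences. Still open, on these data alone, is whether the nitro group contributes at all, which plain phenyl would test. An amine or a carboxylic acid on this phenyl ring also remains to be read.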